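The source may hold more compounds than are shown below. What is called first, only, known or untested is meant among the compounds shown, and "the series" means these compounds.

Compound 1 `Cc1nc([N+](=O)[O-])cn1CC(O)CN1CCN(c2cccc(Cl)c2Cl)CC1` is the anchor here: in a toxicity assay on HeLa cells (Homo sapiens) for cytotoxicity, read by MTT assay, with a stated time of 24 h (a lower number here means a stronger inhibitor, a higher number a weaker inhibitor), compound 1 gives 3620000 nM. Compound 2 `CCN1CCN(CC(O)Cn2cc([N+](=O)[O-])nc2C)CC1` carries ethyl in place of 2,3-dichlorophenyl on the amine nitrogen in the ring. In this assay compound 2 gives only a limit, > 5000000 nM, and not a number. On the two values shown compound 2 thus stands at the weak end, since (the limit of > 5000000 nM in this assay, at which 1 of the 2 values shown sits). Within the data shown here, the only measured step, an at least 1.3-fold higher number from compound 1 to compound 2 (0.14 log units; that floor lies within the scatter), is the one that bears on compound 3 `Cc1nc([N+](=O)[O-])cn1CC(O)CN1CCN(c2ccccn2)CC1`, which differs from compound 2 by pyridin-2-yl in place of ethyl on an amine nitrogen in a ring. That measured step was small enough to lie within the scatter and ran toward a weaker number when the aryl group left the nitrogen; the change to compound 3 puts an aromatic ring back onto that same nitrogen, so a step in the other direction, toward the number of compound 1, is expected, though it need not exceed the scatter. The step from compound 2 to compound 3 is estimated as an at least 1.3-fold lower number from compound 2 to compound 3 (0.11 log units; that floor lies within the scatter). Compound 3 is accordingly expected at 3800000 nM, between 1500000 nM and 9000000 nM.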

Compound 3, half-maximal inhibitory concentration: > 5000000 nM
Compound 3 ended at the assay's limit (the forecaster's own chance of this, stated with the estimate: 40%); middle value at least 1.3-fold (0.11 log units) away from the limit.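

In this assay compound 3, like compound 2, gives only a limit and not a number, so pyridin-2-yl and ethyl on this amine nitrogen cannot be told apart, and the step between those two compounds cannot be read. Putting pyridin-2-yl in place of 2,3-dichlorophenyl gives an at least 1.3-fold higher number from compound 1 to compound 3 (0.14 log units; that floor lies within the scatter), so this change, like the ethyl change before it, is not shown to move the number beyond the scatter. What the earlier compounds did not show is that an aromatic ring on this nitrogen can still leave the value at the limit, so having an aromatic ring there does not alone yield a measured number, and the limit now covers more of the compounds shown: the limit of > 5000000 nM in this assay, at which 2 of the 3 values shown sit.

From the compounds shown here alone, how far the true values of compound 2 and compound 3 lie from that limit stays open, so no order among the three compounds can be given. Also open, going by these compounds, is whether another group on this nitrogen, such as an unsubstituted phenyl, a benzyl or a longer chain ending in a carboxylic acid, would give a number inside the range of the assay.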